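Moving a Methylpiperidine

A few compounds are considered here, and "the series" means these few. Any claim that something is new, unique, unknown or untested is made for them only; others in the source may bear on it.

Of the compounds shown here, three have been measured in an ADME assay on a cell-free system (plasma, Mus musculus) for metabolic stability, read by LC-MS, tested at 2 uM; on this read-out lower numbers stand for a shorter-lived compound and higher numbers for a longer-lived compound. Compound 1 `O=C(NCCCCc1ccccc1)n1c2c(oc1=O)CNCC2` gives > 2 h, which is a limit of the assay and not a number. Compound 2 `CC(C)CN1CCC(c2ccc3c(c2)oc(=O)n3C(=O)NCCCCc2ccccc2)CC1` gives 1 h. Going by the values given here, compound 3 `CC(C)CNC(=O)n1c(=O)oc2cc(C3CCCCN3C)ccc21` gives 0.5 h, and this value lies within the usual scatter of the one for compound 2. Among the compounds with values here, compound 3 therefore stands level with its only numerical neighbour, and the two cannot be separated on these data.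

The next structure is compound 4 `CC(C)CNC(=O)n1c(=O)oc2cc(C3CCN(C)CC3)ccc21`, which has the same atoms as compound 3, joined differently: 1-methylpiperidin-4-yl in place of 1-methylpiperidin-2-yl on an aromatic carbon. In words, 1-methylpiperidin-4-yl takes the place of 1-methylpiperidin-2-yl on an aromatic carbon, and the rest of the molecule is unchanged. Within the data shown here, no measured pair of compounds isolates this change, and compounds 2 and 3 differ in more than one place, so no direct precedent exists in this assay.

With so little to go on, no shift beyond the scatter is expected. Among the measured compounds shown here, the only nearby number to lean towards is that of compound 2, at 1 h. A small expected rise, a 1.4-fold higher number from compound 3 to compound 4 (0.15 log units; within the scatter), would stay within the scatter. For compound 4 the estimated half-life is 0.7 h, with an expected range of 0.3 h to 1.7 h.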

Compound 4, half-life: 1.33 h
For compound 4 the middle estimate is 1.9-fold (0.28 log units) below the measured one, within the range that was stated.
By their numbers in this assay, from the lowest: compounds 3, 2 and 4 (each within the scatter of the next, the first and the last beyond it). At a limit, above all of these: compound 1.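

In this assay, the point at which the methylpiperidine joins the aromatic carbon proves to matter: 1-methylpiperidin-4-yl in place of 1-methylpiperidin-2-yl gives a 2.7-fold higher number from compound 3 to compound 4 (0.42 log units; beyond the scatter). Going by these compounds alone, this is the first change that stands alone in one place, and the earlier compounds offered no such reading of this position. The two groups match in heavy atoms, hetero atom and hydrogen-bond counts, so those counts do not tell compound 3 and compound 4 apart, and nothing at hand gives a reason for the step.

As far as these compounds go, this rests on a single pair, so it remains open whether the same swap would read the same way on another side chain, such as the longer chain ending in a phenyl ring that compound 2 carries. Also open is where 1-methylpiperidin-3-yl would fall relative to the two groups shown, and whether a ring with a free amine or a larger group than methyl on the nitrogen would shift the half-life further.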